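The compounds below may be only part of what the source reports. "The series", "measured", "known", "first", "only" and "open" are said of these compounds alone.

Compound 1, `CC#CCn1c(N2CCC[C@@H](N)C2)nc2c1c(=O)n(Cc1ccccc1C(=O)O)c(=O)n2C`, in an ADME assay on isolated protein for inhibition of Dipeptidyl peptidase 9 (Homo sapiens), with stated times of 15 min, 60 s and 20 min (a lower number here means a stronger inhibitor, a higher number a weaker inhibitor), gives > 100000 nM, which is a limit of the assay.
Compound 2, `CC#CCn1c(N2CCC[C@@H](N)C2)nc2c1c(=O)n(Cc1cc(OC)ccc1C(=O)O)c(=O)n2C`, in this assay gives > 100000 nM, also a limit of the assay.

For the measured compounds named here, compound 2 therefore stands only at a limit in this assay, with no number of its own, and the one further value shown is likewise a limit. Going by the values given here, the step from compound 1 to compound 2, a step that the two limits leave unreadable from compound 1 to compound 2, is the only measured step and cannot be read, since the limit of > 100000 nM in this assay, at which 2 of the 2 values shown sit, marks where both values sit. Compound 3, `CC#CCn1c(N2CCC[C@@H](N)C2)nc2c1c(=O)n(Cc1ccc(Cl)cc1C(=O)OC)c(=O)n2C`, is not yet measured; it differs from compound 2 by 4-chloro-2-(methoxycarbonyl)phenyl in place of 2-carboxy-5-methoxyphenyl on a saturated chain carbon bound to an aromatic nitrogen. Among the compounds with values here, no measured step bears on this change. The expected step of a number no higher from compound 2 to compound 3 (the limit leaves the size open) is therefore uncertain, and compound 3 is estimated at 100000 nM in this assay, within 10000 nM to 300000 nM, most likely again as a limit.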

Compound 3, half-maximal inhibitory concentration: > 100000 nM
Compound 3: a limit, no number (the forecaster's own chance of this, stated with the estimate: 70%); the middle value sits exactly at the limit.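

Compound 3 also sits at a limit of the assay, so neither its step from compound 1 nor its step from compound 2 can be read: the limit of > 100000 nM in this assay, at which 3 of the 3 values shown sit. The compounds shown leave open whether any of these changes alters inhibition in this assay, since none of compound 1, compound 2 or compound 3 has a number of its own.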